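Working notes: from compound 2 to compound 3

The source may hold more compounds than are shown below. What is called first, only, known or untested is meant among the compounds shown, and "the series" means these compounds.

Measured in a functional assay on PC-3 cells (Homo sapiens) for antiproliferative activity, read by MTT assay, with a stated time of 72 h; a lower number here means a stronger inhibitor, a higher number a weaker inhibitor
Compound 1 `CCCC(=O)NNC(=O)c1csc2ncc(-c3ccc(C)cc3)n12` gives 53500 nM
Compound 2 `CC(=O)NNC(=O)c1csc2ncc(-c3ccc(Br)cc3)n12` gives 12700 nM

Compound 2 holds the lower of the two numbers, and its gap to compound 1 lies beyond the scatter. Compound 3 `CCCC(=O)NNC(=O)c1csc2ncc(-c3ccc(Br)cc3)n12` differs from compound 2 by ethyl in place of hydrogen on a saturated chain carbon bound to a carbonyl carbon with ethyl in place of hydrogen on a saturated chain carbon bound to a carbonyl carbon. Compound 1 at 53500 nM also carries the propylcarbonyl group but differs elsewhere too, so it offers only a weak hint of a higher number. The expected 1.6-fold higher number from compound 2 to compound 3 (0.20 log units; within the scatter) is small, upward and probably within the scatter. The value expected for compound 3 is 20000 nM within an estimated range of 7000 nM to 50000 nM in this assay for now.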

Compound 3, half-maximal inhibitory concentration: 58500 nM
Estimate against measurement, compound 3: 2.9-fold (0.47 log units) below; measured number above the stated range.
By their numbers in this assay, from the lowest: compound 2; then compounds 1 and 3 (each within the scatter of the next).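

In this assay the acyl chain proves sensitive: ethyl in place of hydrogen on a saturated chain carbon bound to a carbonyl carbon gives a 4.6-fold higher number from compound 2 to compound 3 (0.66 log units; beyond the scatter) and so favours acetyl over propylcarbonyl with bromo held constant. With propylcarbonyl held constant, bromo in place of methyl on an aromatic carbon gives a 1.1-fold higher number from compound 1 to compound 3 (0.04 log units; within the scatter) and leaves the two compounds inseparable. Nothing measured accounts for the chain effect. Open, as far as these compounds go, is whether a hydroxyl or an amine on the chain would behave like ethyl. Also open, from the compounds shown here alone, is whether the aromatic change stays silent with acetyl in place.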